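This account rests on a few compounds, and the source may have more. Where it says the series, first, only, none or still open, it means among the compounds named here.

Working notes on the series in an assay on HEK293 cells for inhibition of diacylglycerol lipase-alpha (Homo sapiens), read by colorimetric assay, with stated times of 30 min, 60 s and 20 min; on this read-out lower numbers stand for stronger inhibition and higher numbers for weaker inhibition.

Compound 1 `O=C(N1CCC=C[C@@H]1Cc1ccccc1)n1cc(-c2ccc(-c3ccccc3)cc2)nn1` carries a benzyl substituent on the core and gives 0.794 nM in this assay. Compound 2 `O=C(N1CCC=C[C@@H]1COCc1ccccc1)n1cc(-c2ccc(-c3ccccc3)cc2)nn1` differs only in the substituent, and the change brings a 32-fold higher number from compound 1 to compound 2 (1.50 log units; beyond the scatter), so compound 2 gives 25.1 nM. Compound 3 `O=C(N1C[C@H](O)C=C[C@@H]1COCc1ccccc1)n1cc(-c2ccc(-c3ccccc3)cc2)nn1` adds a hydroxy group to the ring of compound 2, which yields no change at the digits printed from compound 2 to compound 3 (within the scatter); compound 3 gives 25.1 nM. Compound 3 therefore stands level with compound 2 at the digits recorded, the two together being the highest numbers among the three, with compound 1 the lowest by a wide margin.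

Compound 4 `O=C(N1C[C@H](O)C=C[C@@H]1Cc1ccccc1)n1cc(-c2ccc(-c3ccccc3)cc2)nn1` keeps the hydroxy group of compound 3 and changes the side chain: phenyl in place of benzyloxy on a saturated chain carbon bound to a saturated ring carbon. This is the exact reverse of the change between compound 1 and compound 2, where the step was a 32-fold higher number from compound 1 to compound 2 (1.50 log units; beyond the scatter), and the hydroxy group, by the step from compound 2 to compound 3, showed no separate effect on the number. A large drop in this assay is therefore expected, of roughly the same size as that earlier step, only in the opposite direction. For compound 4 the expected step is a 25-fold lower number from compound 3 to compound 4 (1.40 log units; beyond the scatter). Compound 4 is estimated at 1 nM, with a plausible range from 0.3 nM to 4 nM.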

Compound 4, half-maximal inhibitory concentration: 15.9 nM
Compound 4: middle estimate off by 16-fold (1.20 log units), on the low side; measured number outside the range, above it.
By their numbers in this assay, from the lowest: compound 1; then compounds 4, 2 and 3 (each within the scatter of the next).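

With the hydroxy group on the ring, phenyl in place of benzyloxy on a saturated chain carbon bound to a saturated ring carbon gives only a 1.6-fold lower number from compound 3 to compound 4 (0.20 log units; within the scatter), so the side-chain change that is large without the hydroxy group does not show up with it: the same change on two cores in this assay, a 32-fold higher number (1.50 log units; beyond the scatter) from compound 1 to compound 2 and a 1.6-fold higher number (0.20 log units; within the scatter) from compound 4 to compound 3, 20-fold (1.30 log units) apart, beyond the scatter of two such steps. Hydroxy in place of hydrogen on a saturated ring carbon, silent in the benzyloxy pair, gives a 20-fold higher number from compound 1 to compound 4 (1.30 log units; beyond the scatter) in the benzyl pair, so its step also depends on the side chain it is paired with: the same change on two cores in this assay, no change at the digits printed (within the scatter) from compound 2 to compound 3 and a 20-fold higher number (1.30 log units; beyond the scatter) from compound 1 to compound 4, 20-fold (1.30 log units) apart, beyond the scatter of two such steps. The two changes therefore do not add in this assay, and compound 1, with benzyl and no hydroxy group, gives 0.794 nM, the lowest number of the four compounds.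

As far as these compounds go, whether the step in the benzyl pair belongs to the hydroxy group itself or to any group on that saturated ring carbon stays open, and a methoxy group or an amine there would separate the two. It is also open whether a longer chain in place of benzyl would follow benzyl or benzyloxy, and the compounds shown give no reason why the two steps differ.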